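This account rests on a few compounds, and the source may have more. Where it says the series, first, only, none or still open, it means among the compounds named here.

Measured so far:
compound 1 `CNCc1cc(-c2cccnc2Cl)n(S(=O)(=O)c2cccnc2)c1` — 92%
compound 2 `CNCc1cc(-c2cnccc2C)n(S(=O)(=O)c2cccnc2)c1` — -54%

Both were tested in a functional assay on the whole organism (strain Jcl:SD) for inhibition, with Rattus norvegicus as the target, with stated times of 3 min and 3 h, at a dose of 1 mg/kg by the intravenous route; a higher number here means more inhibition at the dose given (going by the name of the read-out), a lower number less inhibition. Compound 2 gives the lower of the two numbers; its nearest neighbour is compound 1, and the gap between them is one step that is beyond the scatter: a number 146 percentage points lower from compound 1 to compound 2 (beyond the scatter). Compound 3 `CNCc1cc(-c2ccncc2F)n(S(=O)(=O)c2cccnc2)c1` has not been measured yet. It differs from compound 2 in one place: 3-fluoropyridin-4-yl in place of 4-methylpyridin-3-yl on an aromatic carbon. For the measured compounds named here, the only measured step that bears on this change is the one from compound 1 to compound 2, where exchanging one pyridyl group for another on the same aromatic carbon moved the read-out by a large amount. Compound 3 again exchanges the whole pyridyl group at that carbon, so a large step is expected rather than none, most likely back upward since compound 2 sits at the bottom. The expected change is a number 94 percentage points higher from compound 2 to compound 3 (beyond the scatter). For compound 3 the estimate is 40%, with a range from -30% to 85%.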

Compound 3, a percentage reported as inhibition, in the whole organism at one dose (the size of the read-out at that dose, not a potency) in the Rattus norvegicus assay: 48%
Estimate against measurement, compound 3: 8 percentage points below; measured number inside the range.
By their numbers in the Rattus norvegicus assay, from the lowest: compound 2; then compound 3; then compound 1.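

In the Rattus norvegicus assay, swapping one substituted pyridyl group for another on this carbon gives a number 102 percentage points higher from compound 2 to compound 3 (beyond the scatter) and a number 44 percentage points lower from compound 1 to compound 3 (beyond the scatter), so the choice of pyridyl group matters greatly even though the entering and leaving groups have the same heavy-atom count. For the compounds shown here, in a physicochemical assay for lipophilicity, read by HPLC, at pH 7.4 (on this read-out lower numbers stand for lower lipophilicity and higher numbers for higher lipophilicity), compound 2 gives -0.51 and compound 3 gives -0.34, which is a number 0.17 log units higher from compound 2 to compound 3 (within the scatter), so the large step in inhibition has no counterpart on this read-out. No information is available to explain these differences.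

From the compounds shown here alone, each change alters the substituent and the way the pyridine is attached together, so the share of each stays open. An unsubstituted pyridin-3-yl group, or a pyridine carrying an amino group, would help separate them.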